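The compounds below may be only part of what the source reports. "The series", "measured", "known", "first", "only" and "open" are said of these compounds alone.

In a functional assay on A549 cells (Homo sapiens) for inhibition, read by CCK-8 assay, with a stated time of 72 h, tested at 10 uM (a higher number here means more inhibition of growth at the concentration tested, a lower number less inhibition of growth), compound 1 (`CN(C)C(=O)c1cc2cnc(Nc3ccc(NC(=O)C4(C(=O)Nc5ccc(F)cc5)CC4)cc3)nc2n1C1CCCC1`) gives 102% and compound 2 (`CN(C)C(=O)c1cc2cnc(Nc3ccc(NC(=O)C4(C(=O)Nc5cccc(Cl)c5)CC4)cc3)nc2n1C1CCCC1`) gives 90.7%, the lower of the two numbers. Compound 3 (`CN(C)C(=O)c1cc2cnc(Nc3ccc(NC(=O)C4(C(=O)Nc5ccc(Br)cc5)CC4)cc3)nc2n1C1CCCC1`) carries 4-bromophenyl in place of 3-chlorophenyl on an amide-type nitrogen. Going by the values given here, the one measured step at this place, a number 11.3 percentage points lower from compound 1 to compound 2 (beyond the scatter), is modest and replaced 4-fluorophenyl with 3-chlorophenyl. Among the compounds with values here, compound 3 again has a 4-halophenyl group, so a small upward move in this assay is expected, no larger than that step. The expected change is a number 4.3 percentage points higher from compound 2 to compound 3 (within the scatter). For compound 3 the estimated value is 95%, with a range of 82% to 106%.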

Compound 3, percent growth inhibition at one concentration: 90.3%
Beside the measured number, compound 3's estimate is 4.7 percentage points above it, within the range that was stated.
By their numbers in this assay, from the lowest: compounds 3 and 2 (each within the scatter of the next); then compound 1.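

In this assay, 4-bromophenyl and 3-chlorophenyl on the amide-type nitrogen cannot be told apart (a number 0.4 percentage points lower from compound 2 to compound 3 (within the scatter)). Bromo in place of fluoro on an aromatic carbon gives a modest step (a number 11.7 percentage points lower from compound 1 to compound 3 (beyond the scatter)), so a 4-halophenyl group alone does not keep the number seen with 4-fluorophenyl, and two different replacements of that group now give a similar step. No evidence is available to explain either step. The compounds shown leave open how an unsubstituted phenyl, a 4-methoxyphenyl or a pyridyl group on this nitrogen would read.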